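Removing the hydroxyethyl end from compound 3

The compounds below may be only part of what the source reports. "The series", "measured", "known", "first", "only" and "open" are said of these compounds alone.

Compound 1 `O=S(=O)(/C=C/c1ccc(O)c(O)c1)CCC1CCCC1` gives 6800 nM
Compound 2 `O=S(=O)(/C=C/c1ccc(O)c(O)c1)CC1CCCO1` gives 10500 nM
Compound 3 `O=S(=O)(/C=C/c1ccc(O)c(O)c1)CCCCCCCCCO` gives 7500 nM
Compound 4 `CCCCCCCS(=O)(=O)/C=C/c1ccc(O)c(O)c1` awaits measurement

In a functional assay, read by fluorescence and spectrophotometry, with a stated time of 1 h (on this read-out higher numbers stand for an effect only at larger amounts of compound and lower numbers for an effect already at smaller amounts), compound 3 lies within the usual scatter of both compound 1 and compound 2, so these values set no order. Compound 4 carries hydrogen in place of 2-hydroxyethyl on a saturated chain carbon, seven bonds along the chain from a sulfonyl sulfur. Among the measured compounds shown here, the only measured step (a 1.5-fold higher number from compound 1 to compound 2 (0.19 log units; within the scatter)) changes a different group and stays within the scatter, so it offers only loose guidance. The expected step of a 1.1-fold lower number from compound 3 to compound 4 (0.03 log units; within the scatter) in this assay is therefore none beyond the scatter. Compound 4 is estimated at 7000 nM (expected range 3000 nM to 16000 nM).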

Compound 4, half-maximal effective concentration: 7100 nM
Compound 4: middle estimate off by 1.0-fold (0.01 log units), on the low side; low and high end bracket the measured number.
By their numbers in this assay, from the lowest: compounds 1, 4, 3 and 2 (each within the scatter of the next).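

In this assay, losing the 2-hydroxyethyl group, and with it a hydrogen-bond donor and acceptor, gives no step beyond the scatter: a 1.1-fold lower number from compound 3 to compound 4 (0.02 log units; within the scatter). The plain chain of compound 4 also stays within the scatter of the compounds carrying oxolan-2-yl or cyclopentyl, with a 1.5-fold lower number from compound 2 to compound 4 (0.17 log units; within the scatter) and a 1.0-fold higher number from compound 1 to compound 4 (0.02 log units; within the scatter). No supporting measurement is available to explain these results.

Still open, going by these compounds, is whether an amine or a carboxylic acid in place of 2-hydroxyethyl on this saturated chain carbon would give a step beyond the scatter.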